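Adding a methyl to the furan of compound 3

A few compounds are considered here, and "the series" means these few. Any claim that something is new, unique, unknown or untested is made for them only; others in the source may bear on it.

In a functional assay on HCT-15 cells (Homo sapiens) for cytotoxicity, read by ELISA, with a stated time of 4 days (a higher number here means a weaker inhibitor, a lower number a stronger inhibitor), compound 1 `Cc1ccsc1-c1cc(-c2ccco2)cc(-c2ccccc2Cl)n1` gives 540 nM, compound 2 `Cc1ccsc1-c1cc(-c2ccoc2)cc(-c2ccco2)n1` gives 640 nM and compound 3 `Clc1ccc(-c2cc(-c3ccoc3)cc(-c3ccco3)n2)s1` gives 1280 nM. Compound 3 sits within the scatter of compound 2 and, on the two values, beyond the scatter above compound 1.

Compound 4 `Cc1ccc(-c2cc(-c3ccoc3)cc(-c3ccc(Cl)s3)n2)o1` differs from compound 3 in one place, furan-2-yl to 5-methylfuran-2-yl: methyl in place of hydrogen on an aromatic carbon. This puts methyl in place of hydrogen on an aromatic carbon, next to the ring oxygen.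

Going by the values given here, only one measured step links two compounds that differ in one place: a 2.0-fold higher number from compound 2 to compound 3 (0.30 log units; within the scatter). That step exchanges 3-methylthiophen-2-yl for 5-chlorothiophen-2-yl and leaves the furan-2-yl untouched, so it is only indirect evidence. Among the compounds with values here, no measured compound carries 5-methylfuran-2-yl, and the series offers no direct precedent for this change. With nothing pointing either way, no shift beyond the scatter is expected, and the range is kept wide to reflect the missing precedent. The expected step is a 1.2-fold lower number from compound 3 to compound 4 (0.07 log units; within the scatter). For compound 4 the estimated value is 1100 nM, with an expected range of 400 nM to 3000 nM.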

Compound 4, half-maximal inhibitory concentration: 790 nM
Compound 4: the middle estimate sits 1.4-fold (0.14 log units) above what was measured, within the range that was stated.
By their numbers in this assay, from the lowest: compounds 1, 2, 4 and 3 (each within the scatter of the next, the first and the last beyond it).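

In this assay, going by these compounds alone, methyl in place of hydrogen on an aromatic carbon of the furan, next to the ring oxygen and two ring bonds from the ring atom that bears a large group, gives a 1.6-fold lower number from compound 3 to compound 4 (0.21 log units; within the scatter), and this is the first reading at this position, since the earlier step between compounds that differ in one place changed only the thiophene substituent. On this single pair, the carbon accepts a methyl without a shift beyond the scatter, so furan-2-yl and 5-methylfuran-2-yl cannot be told apart in this cytotoxicity read-out with 5-chlorothiophen-2-yl elsewhere on the core. No accompanying measurement speaks to what lies behind this result.

Going by these compounds, whether a group larger than methyl at this carbon, such as ethyl, a longer chain, an amine or a carboxylic acid, would also stay within the scatter of compound 3 remains open. Also open, on these data alone, is whether the methyl would read the same way with 3-methylthiophen-2-yl in place of 5-chlorothiophen-2-yl, the setting of compound 2.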